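The source may hold more compounds than are shown below. What is called first, only, known or untested is meant among the compounds shown, and "the series" means these compounds.

Measured in a functional assay for inhibition, with Homo sapiens as the target; a lower number here means a stronger inhibitor, a higher number a weaker inhibitor:
- compound 1 `O=C(O)COc1cccc(CCc2nc(-c3ccccc3)c(-c3ccccc3)o2)c1`: 1200 nM
- compound 2 `CCOC(=O)/C(=C/c1cccc(OCC(=O)OC)c1)c1nc(-c2ccccc2)c(-c2ccccc2)o1`: 19700 nM
- compound 3 `CCOC(=O)/C(=C\c1cccc(OCC(=O)OC)c1)c1nc(-c2ccccc2)c(-c2ccccc2)o1`: 2000 nM

In this assay, compound 3 gives 2000 nM, which lies within the scatter of compound 1 and well under compound 2. The change under study leads to compound 4 `CCOC(=O)/C(=C\c1cccc(OCC(=O)OC(C)(C)C)c1)c1nc(-c2ccccc2)c(-c2ccccc2)o1` and is tert-butyl in place of methyl on an oxygen next to a carbonyl group, that is, methoxycarbonyl to tert-butoxycarbonyl, with tert-butyl in place of methyl on an oxygen next to a carbonyl group.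

Within the data shown here, no measured pair tests this change directly. Among the measured compounds shown here, the only step available is a 9.9-fold lower number from compound 2 to compound 3 (0.99 log units; beyond the scatter), and it rests on (the fact that compounds 2 and 3 differ only in the configuration as drawn). That step concerns a double bond and not the ester group, so it bears on the new change only indirectly. It shows that these compounds can move beyond the scatter without any change in atoms, and it serves as a rough upper guide to the size of step here.

A step near the edge of the scatter is therefore the working expectation, leaning towards a higher number, though the direction is a weak call. The expected step is a 1.8-fold higher number from compound 3 to compound 4 (0.24 log units; within the scatter). For compound 4 the estimated value is 3500 nM, with an expected range from 900 nM to 14000 nM.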

Compound 4, half-maximal inhibitory concentration: > 60000 nM
Compound 4: only a limit was reported (the forecaster's own chance of this, stated with the estimate: 5%); middle value at least 17-fold (1.23 log units) away from the limit.
By their numbers in this assay, from the lowest: compounds 1 and 3 (each within the scatter of the next); then compound 2. At a limit, above all of these: compound 4.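

In this assay compound 4 gives > 60000 nM, which is a limit of the assay and not a number. Even so, tert-butyl in place of methyl on an oxygen next to a carbonyl group can be read as an at least 30-fold higher number from compound 3 to compound 4 (1.47 log units; beyond the scatter), so this ester end of the molecule is not a neutral site for substitution, and a change of alkyl group there alone is enough to take a compound out of the measurable range. The earlier compounds showed movement only through the double bond, with a 9.9-fold lower number from compound 2 to compound 3 (0.99 log units; beyond the scatter), and left the ester untested, since that pair holds the same atoms and bonds: the fact that compounds 2 and 3 differ only in the configuration as drawn

The compounds shown do not say whether the number climbs gradually with the size of the group on this oxygen or jumps only at tert-butyl, and isopropyl in that place would be the informative intermediate. They also give no property of tert-butyl that accounts for the step, and the full size of the step stays unknown while compound 4 stands at a limit.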